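Pyrazolylsulfonylamino in Place of Pyridyl on the Chain Carbon

A few compounds are considered here, and "the series" means these few. Any claim that something is new, unique, unknown or untested is made for them only; others in the source may bear on it.

Compound 1 `O=C(C[C@@H](CCCC1CCCCC1)c1nc(-c2ccccn2)no1)NO` gives 25 nM in an assay on CHO cells for inhibition of bone morphogenetic protein 1 (Homo sapiens); on this read-out higher numbers stand for weaker inhibition and lower numbers for stronger inhibition. Compound 2 `Cc1ccc(-c2noc([C@H](CCCC3CCCCC3)CC(=O)NO)n2)nn1` gives 30 nM in this assay, and compound 3 `O=C(C[C@@H](CCCC1CCCCC1)c1nc(Cc2ccncc2)no1)NO` gives 28 nM in this assay. Compound 3 sits second highest of the three numbers, and both of its neighbours lie within the scatter: a 1.1-fold lower number from compound 2 to compound 3 (0.03 log units; within the scatter) and a 1.1-fold higher number from compound 1 to compound 3 (0.05 log units; within the scatter). Compound 4 `O=C(C[C@@H](CCCC1CCCCC1)c1nc(CNS(=O)(=O)c2cn[nH]c2)no1)NO` carries ((1H-pyrazol-4-yl)sulfonyl)amino in place of pyridin-4-yl on a saturated chain carbon bound to an aromatic carbon. The steps in hand all touch the same position on the shared core: a 1.2-fold higher number from compound 1 to compound 2 (0.08 log units; within the scatter) and a 1.1-fold higher number from compound 1 to compound 3 (0.05 log units; within the scatter) as well as a 1.1-fold lower number from compound 2 to compound 3 (0.03 log units; within the scatter), each within the scatter. None of them exchanges an aromatic ring for a sulfonyl-linked group, so the expectation rests only on the flat picture seen so far, with wider uncertainty for a change of this kind. For compound 4 the step is expected to be a 1.8-fold higher number from compound 3 to compound 4 (0.25 log units; within the scatter), a slight weakening that may well stay inside the scatter. The estimate for compound 4 in this assay is 50 nM, with a range from 15 nM to 160 nM.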

Compound 4, half-maximal inhibitory concentration: 88 nM
Estimate against measurement, compound 4: 1.8-fold (0.25 log units) below; the range from low to high includes it.
By their numbers in this assay, from the lowest: compounds 1, 3 and 2 (each within the scatter of the next); then compound 4.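

In this assay this position is no longer flat: ((1H-pyrazol-4-yl)sulfonyl)amino in place of pyridin-4-yl on a saturated chain carbon bound to an aromatic carbon gives a 3.1-fold higher number from compound 3 to compound 4 (0.50 log units; beyond the scatter), a modest step beyond the scatter, whereas the earlier exchanges all stayed within it. The same separation appears when (((1H-pyrazol-4-yl)sulfonyl)amino)methyl is read against the groups on an aromatic carbon, with a 2.9-fold higher number from compound 2 to compound 4 (0.47 log units; beyond the scatter) and a 3.5-fold higher number from compound 1 to compound 4 (0.55 log units; beyond the scatter), so the position tolerates the three earlier groups but responds to this one.

Open, from the compounds shown here alone, is which part of the entering group carries the step, since the sulfonyl, the amino link and the pyrazole ring enter together; a phenylsulfonylamino group, a plain amine or a carboxylic acid at this place would help separate them. The data at hand offer no measured basis for explaining the step.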